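A few compounds are considered here, and "the series" means these few. Any claim that something is new, unique, unknown or untested is made for them only; others in the source may bear on it.

Measured so far in a functional assay on the whole organism (Abdomen, strain Swiss albino) with Mus musculus as the target, with stated times of 10 min and 5 min, at a dose of 15 mg/kg by the oral route; a higher number here means a stronger effect of the compound at the dose given, a lower number a weaker effect:

Compound 1 `O=C1C2ON=C(c3cn(-c4ccccc4)nc3-c3ccc(Br)cc3)C2C(=O)N1c1ccccc1` gives 2.75%.
Compound 2 `CN1C(=O)C2ON=C(c3cn(-c4ccccc4)nc3-c3ccc(Br)cc3)C2C1=O` gives 9.81%.
Compound 3 `O=C1C2ON=C(c3cn(-c4ccccc4)nc3-c3ccc(Cl)cc3)C2C(=O)N1c1ccccc1` gives 23.9%.

Compound 3 stands highest of the three, and its steps to compound 2 and compound 1 are both beyond the scatter. The two cores differ by chloro in place of bromo on an aromatic carbon, and that step reads a number 21.2 percentage points higher from compound 1 to compound 3 (beyond the scatter). Within the bromo core, methyl in place of phenyl on an amide-type nitrogen in a ring gave a number 7.1 percentage points higher from compound 1 to compound 2 (within the scatter).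

Compound 4 `CN1C(=O)C2ON=C(c3cn(-c4ccccc4)nc3-c3ccc(Cl)cc3)C2C1=O` is not yet measured in this assay. It differs from compound 3 by methyl in place of phenyl on an amide-type nitrogen in a ring, the same change as from compound 1 to compound 2, at the same place. Taking the step seen from compound 1 to compound 2 as the guide, and noting that it lay within the scatter, the step from compound 3 to compound 4 is expected to be a number 5.1 percentage points higher from compound 3 to compound 4 (within the scatter). Compound 4 is therefore estimated at 29%, within a range of 15% to 43%, resting on the value of compound 3 23.9% and on a single earlier instance of the same change.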

Compound 4, a percentage reported as activity, at one dose (the size of the read-out at that dose, not a potency): 7.84%
For compound 4 the middle estimate is 21.2 percentage points above the measured one; measured number outside the range, below it.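

In this assay, methyl in place of phenyl on the amide-type nitrogen gives a number 16.1 percentage points lower from compound 3 to compound 4 (beyond the scatter) on the chloro core, so the earlier step on the bromo core is no guide to this one: the same change on two cores in this assay, a number 7.1 percentage points higher (within the scatter) from compound 1 to compound 2 and a number 16.1 percentage points lower (beyond the scatter) from compound 3 to compound 4, 23.1 percentage points apart, beyond the scatter of two such steps

With methyl on that nitrogen, chloro in place of bromo gives a number 2 percentage points lower from compound 2 to compound 4 (within the scatter), so the halogen step also fails to carry over from the phenyl pair: the same change on two cores in this assay, a number 21.2 percentage points higher (beyond the scatter) from compound 1 to compound 3 and a number 2 percentage points lower (within the scatter) from compound 2 to compound 4, 23.1 percentage points apart, beyond the scatter of two such steps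

The two changes are therefore not additive across these four compounds, but the data do not show why, and each step rests on a single pair at one dose.

From the compounds shown here alone, how either core behaves with a longer chain such as butyl on the amide-type nitrogen stays open. Also open, going by these compounds, is whether fluoro on the aromatic carbon would follow the chloro or the bromo compounds.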